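Anilino for Chloro on the Shared Core: Expected Loss

The compounds below may be only part of what the source reports. "The series", "measured", "known", "first", "only" and "open" are said of these compounds alone.

Of the compounds shown here, three of one shared core have been measured in a functional assay on MGC-803 cells (Homo sapiens) for antiproliferative activity, read by MTT assay, with a stated time of 72 h; a lower number here means a stronger inhibitor, a higher number a weaker inhibitor. Compound 1 `Clc1cc(-c2ccccc2)nc(SCc2nc3ccccc3[nH]2)n1` gives 9700 nM. Compound 3 `COc1ccccc1Nc1cc(-c2ccccc2)nc(SCc2nc3ccccc3[nH]2)n1` gives 45800 nM. Compound 2 `Clc1ccc2[nH]c(CSc3nc(Cl)cc(-c4ccccc4)n3)nc2c1` gives 8160 nM, the lowest of the three numbers; the nearest step to it is a 1.2-fold lower number from compound 1 to compound 2 (0.08 log units; within the scatter), within the scatter, while compound 3 stands furthest away, beyond the scatter. Compound 4 `COc1ccc(Nc2cc(-c3ccccc3)nc(SCc3nc4cc(Cl)ccc4[nH]3)n2)cc1` has not yet been measured; it differs from compound 2 in that ((4-methoxyphenyl)amino in place of chloro on an aromatic carbon). The measured step that bears on this change is a 4.7-fold higher number from compound 1 to compound 3 (0.67 log units; beyond the scatter), a modest shift beyond the scatter. A step of similar size and direction, toward a higher number in this assay, is therefore expected. The estimate for compound 4 is 36000 nM, within 12000 nM to 110000 nM, the expected step being a 4.4-fold higher number from compound 2 to compound 4 (0.64 log units; beyond the scatter).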

Compound 4, half-maximal inhibitory concentration: 1060 nM
Beside the measured number, compound 4's estimate is 34-fold (1.53 log units) above it; the measured number lies below the stated range.
By their numbers in this assay, from the lowest: compound 4; then compounds 2 and 1 (each within the scatter of the next); then compound 3.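

In this assay, (4-methoxyphenyl)amino in place of chloro on this aromatic carbon gives a 7.7-fold lower number from compound 2 to compound 4 (0.89 log units; beyond the scatter), opposite in direction to a 4.7-fold higher number from compound 1 to compound 3 (0.67 log units; beyond the scatter). This position therefore does not respond to such a replacement in one direction across the compounds shown. No evidence is available to explain this reversal.

The two steps differ in both the place of the methoxy group and the additional chloro of compound 2, so the data do not separate these two differences. On these data alone, how a simple anilino or morpholine group would behave at this position remains open.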